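The source may hold more compounds than are shown below. What is called first, only, known or untested is meant among the compounds shown, and "the series" means these compounds.

In a toxicity assay on mitochondria from liver (Rattus norvegicus) for inhibition, in the presence of a further agent that is not named here (on this read-out lower numbers stand for stronger inhibition and higher numbers for weaker inhibition), compound 1 `N#Cc1cc(C(=O)N2CCc3ccccc32)cc(I)c1O` gives 53000 nM and compound 2 `N#Cc1cc(C(=O)N2CS(=O)(=O)c3ccccc32)cc(C2CC2)c1O` gives 59000 nM as its value, and the two lie within the usual scatter of each other. Compound 3 `CC(C)c1cc(C(=O)N2CS(=O)(=O)c3ccccc32)cc(C#N)c1O` has isopropyl in place of cyclopropyl on an aromatic carbon and has not yet been measured. For the measured compounds named here, no measured pair differs in one place, so nothing measured sizes this change, and no step beyond the scatter is expected in this assay in either direction. The expected move is a 1.1-fold lower number from compound 2 to compound 3 (0.03 log units; within the scatter) and stays within the scatter. Compound 3 is estimated at 55000 nM with 25000 nM to 120000 nM as the expected range.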

Compound 3, half-maximal inhibitory concentration: 12000 nM
Compound 3: the middle estimate sits 4.6-fold (0.66 log units) above what was measured; measured number outside the range, below it.
By their numbers in this assay, from the lowest: compound 3; then compounds 1 and 2 (each within the scatter of the next).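

In this assay, the group on the aromatic carbon ortho to a hydroxy group matters to the read-out: isopropyl in place of cyclopropyl gives a 4.9-fold lower number from compound 2 to compound 3 (0.69 log units; beyond the scatter), although both groups have 3 heavy atoms and neither has a hydrogen-bond donor or acceptor. For the compounds shown here, this is the only step here from a pair differing in one place, and it separates a group with a three-membered ring from one with no ring. Nothing available accounts for the step. The compounds shown leave open how a longer chain such as butyl or an amine would read on this carbon, and whether the step would carry over to the core of compound 1.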